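Imidazopyridine urea replacing the benzisoxazole in a piperazine series

The compounds below may be only part of what the source reports. "The series", "measured", "known", "first", "only" and "open" are said of these compounds alone.

Going by the values given here, compound 2 `O=C(Nc1noc2ccccc12)N1CCN(Cc2cccc(Oc3ccc(Cl)cc3)c2)CC1` is the lower of the two numbers measured so far in an assay on isolated protein for inhibition of Fatty-acid amide hydrolase 1 (Homo sapiens), with a stated time of 60 min; on this read-out higher numbers stand for weaker inhibition and lower numbers for stronger inhibition: compound 2 gives 10 nM, while compound 1 `O=C(Nc1cccc2cn[nH]c12)N1CCN(Cc2cccc(Oc3ccc(Cl)cc3)c2)CC1` gives 1300 nM. Among the compounds with values here, the one measured step, a 130-fold lower number from compound 1 to compound 2 (2.11 log units; beyond the scatter), shows that the bicyclic group on the urea nitrogen decides most of the potency. Compound 3 `O=C(Nc1cccn2ccnc12)N1CCN(Cc2cccc(Oc3ccc(Cl)cc3)c2)CC1` carries the change (a group of 9 heavy atoms (7 carbon, 2 nitrogen; one five-membered aromatic ring with 2 hetero atoms, one six-membered aromatic ring with 1 hetero atom) in place of a group of 9 heavy atoms (7 carbon, 1 nitrogen, 1 oxygen; one five-membered aromatic ring with 2 hetero atoms, one six-membered aromatic ring of carbon only), on an amide-type nitrogen). Within the data shown here, no measured step exchanges this exact pair of groups; the step from compound 1 to compound 2 bears on it only by showing how wide the swing from one bicyclic group to another can be. Since compound 3 shares with compound 2 the absence of the ring-bound hydrogen found in compound 1, a modest loss rather than a large one is expected, a 4.0-fold higher number from compound 2 to compound 3 (0.60 log units; beyond the scatter). Compound 3 is therefore estimated at 40 nM, with a range from 8 nM to 300 nM.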

Compound 3, half-maximal inhibitory concentration: 310 nM
Compound 3: middle estimate off by 7.8-fold (0.89 log units), on the low side, and the stated range ends below it.
By their numbers in this assay, from the lowest: compound 2; then compound 3; then compound 1.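

On the amide-type nitrogen, two bicyclic groups that match in heavy atoms, hydrogen-bond donors and acceptors and net charge still give a 31-fold higher number from compound 2 to compound 3 (1.49 log units; beyond the scatter) in this assay, so those counts alone do not set the potency at this position. The second step, a 4.2-fold lower number from compound 1 to compound 3 (0.62 log units; beyond the scatter), is much smaller, so lacking the ring-bound hydrogen of compound 1 does not by itself bring a group to the level of compound 2. No data shown here explain the gap between these groups.

The change to compound 3 alters both rings of the group at once, so the contributions of the five-membered ring and the six-membered ring cannot be separated. Going by these compounds, how a single-ring group, such as plain phenyl or pyridine, would compare on this nitrogen remains open.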